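This account rests on a few compounds, and the source may have more. Where it says the series, first, only, none or still open, it means among the compounds named here.

Measured compounds:
- Compound 1, `c1ccc(-c2noc(Cc3c[nH]c4ccccc34)n2)cc1`: in a functional assay on cells (Splenocyte, Mus musculus, strain BALB/c) for inhibition, read by scintillation counting and thymidine incorporation, with stated times of 48 h and 8 h (a higher number here means a weaker inhibitor, a lower number a stronger inhibitor), compound 1 gives > 50000 nM
- Compound 2, `Fc1ccc(-c2noc(Cc3c[nH]c4ccccc34)n2)cc1`: in this assay compound 2 gives 5400 nM
- Compound 3, `Clc1ccc(-c2noc(Cc3c[nH]c4ccccc34)n2)cc1`: in this assay compound 3 gives 22600 nM

The figure for compound 1 is a limit of the assay, not a number (the limit of > 50000 nM in this assay, at which 1 of the 3 values shown sits). Among the two numbers that are known, compound 3 stands highest, and its nearest neighbour is compound 2, as a 4.2-fold higher number from compound 2 to compound 3 (0.62 log units; beyond the scatter) shows. From the unsubstituted compound 1, putting fluoro in place of hydrogen gives an at least 9.2-fold lower number from compound 1 to compound 2 (0.96 log units; beyond the scatter), and putting chloro in place of hydrogen gives an at least 2.2-fold lower number from compound 1 to compound 3 (0.34 log units; beyond the scatter).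

Compound 4, `CCc1ccc(-c2noc(Cc3c[nH]c4ccccc34)n2)cc1`, differs from compound 3 at the same place: ethyl in place of chloro on an aromatic carbon. Going by the values given here, no measured step swaps a halogen for an alkyl group, so the nearest guide is the move from fluoro to chloro, where the larger group gave the weaker inhibitor. On that basis a modest step toward a higher number, or none beyond the scatter, is expected for a 1.3-fold higher number from compound 3 to compound 4 (0.12 log units; within the scatter). Compound 4 is therefore estimated at 30000 nM in this assay, within a range from 8000 nM to 100000 nM.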

Compound 4, half-maximal inhibitory concentration: 7500 nM
For compound 4 the middle estimate is 4.0-fold (0.60 log units) above the measured one, and the stated range ends above it.
By their numbers in this assay, from the lowest: compounds 2 and 4 (each within the scatter of the next); then compound 3. At a limit, above all of these: compound 1.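

In this assay, the step of a 3.0-fold lower number from compound 3 to compound 4 (0.48 log units; beyond the scatter) shows that a larger number after fluoro gives way to a lower one with ethyl: the move from fluoro to chloro had made the inhibitor weaker, but a group with more heavy atoms than chloro, and made of carbon rather than a halogen, does not continue that trend at this place, para to a large group. The comparison with the fluoro compound gives a 1.4-fold higher number from compound 2 to compound 4 (0.14 log units; within the scatter), so among the compounds shown a halogen is not needed here to reach the lowest numbers, and the chloro compound is the one that stands apart from these two. The step of an at least 6.6-fold lower number from compound 1 to compound 4 (0.82 log units; beyond the scatter) adds ethyl to fluoro and chloro as a third group that beats hydrogen at this place, though compound 1 is at a limit and not a number, so this step gives only a minimum size: the limit of > 50000 nM in this assay, at which 1 of the 4 values shown sits.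

The compounds shown leave open whether a longer chain such as propyl, a methoxy group or an amine at this place would give a lower number still. They also do not tell why chloro gives a higher number than both fluoro and ethyl, or whether ethyl would act the same way elsewhere on the core.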